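Swapping a dichlorophenyl for a dimethoxyphenyl on a ketone

The source may hold more compounds than are shown below. What is called first, only, known or untested is meant among the compounds shown, and "the series" means these compounds.

Measured compounds:
compound 1, `COc1ccc(-c2cc(/C=C/C(=O)c3ccc(OC)c(OC)c3)[nH]n2)cc1`, 97%
compound 2, `COc1cc(-c2cc(/C=C/C(=O)c3ccc(Cl)c(Cl)c3)[nH]n2)cc(OC)c1OC`, 102%
compound 3, `COc1ccc(-c2cc(/C=C/C(=O)c3ccc(N)cc3)[nH]n2)cc1`, 97%

Of the compounds shown here, three have been tested in a functional assay on HCT-116 cells (Homo sapiens) for cytotoxicity, read by sulforhodamine B assay, with a stated time of 48 h, tested at 0.01 uM; on this read-out lower numbers stand for a stronger effect and higher numbers for a weaker effect at the one concentration tested. Compound 1 gives 97%, compound 2 gives 102%, and compound 3 gives 97%. Of the three numbers, that of compound 2 is the highest, yet it is separated from compound 1 and from compound 3 by amounts within the usual scatter, so the three cannot be told apart on this read-out.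

Compound 4, `COc1ccc(C(=O)/C=C/c2cc(-c3cc(OC)c(OC)c(OC)c3)n[nH]2)cc1OC`, has not yet been measured in this assay. It differs from compound 2 in one place: 3,4-dimethoxyphenyl in place of 3,4-dichlorophenyl on a carbonyl carbon. For the measured compounds named here, no step between measured compounds is known. Going by the values given here, since every number so far sits close to compound 2 at 102%, the step of a number 4 percentage points lower from compound 2 to compound 4 (within the scatter) is expected to be none beyond the scatter. Compound 4 is estimated at 98%, between 86% and 110%.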

Compound 4, a percentage reported as activity, at one concentration (the size of the read-out at that concentration, not a potency): 99%
Compound 4: the middle estimate sits 1 percentage points below what was measured; the measured number falls inside the stated range.
By their numbers in this assay, from the lowest: compounds 1, 3, 4 and 2 (each within the scatter of the next).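

In this assay, for the compounds shown here, putting 3,4-dimethoxyphenyl in place of 3,4-dichlorophenyl on a carbonyl carbon gives a number 3 percentage points lower from compound 2 to compound 4 (within the scatter), the first comparison here of compounds that differ in one place. At this position, then, the two groups cannot be told apart on this read-out at the one concentration tested. Nothing measured bears on why this is so.

From the compounds shown here alone, whether a carboxylic acid or a longer chain on that carbonyl carbon would give a number beyond the scatter stays open. So does whether these two groups would separate at any other concentration.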